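The compounds below may be only part of what the source reports. "The series", "measured", "known", "first", "only" and "open" are said of these compounds alone.

Measured compounds in a functional assay on ECa-109 cells (Homo sapiens) for antiproliferative activity, read by MTT assay, with a stated time of 72 h; a higher number here means a weaker inhibitor, a lower number a stronger inhibitor:
- compound 1, `CCCSc1nc(N/N=C/c2ccccc2F)c2nnn(Cc3ccccc3)c2n1`: its value of > 64000 nM is a limit of the assay, not a number.
- compound 2, `CCCSc1nc(N/N=C/c2ccc(Cl)cc2)c2nnn(Cc3ccccc3)c2n1`: its value of > 64000 nM is also a limit of the assay.
- compound 3, `CCCSc1nc(N/N=C/c2ccc([N+](=O)[O-])cc2)c2nnn(Cc3ccccc3)c2n1`: 6640 nM, the only numerical value in the set.

For the measured compounds named here, compound 3 therefore stands alone as the one member with a measured half-maximal inhibitory concentration; the other two sit at the limit of > 64000 nM in this assay, at which 2 of the 3 values shown sit. The steps that reach compound 3 are an at least 9.6-fold lower number from compound 1 to compound 3 (0.98 log units; beyond the scatter) and an at least 9.6-fold lower number from compound 2 to compound 3 (0.98 log units; beyond the scatter), both at least modest and beyond the scatter, though their true size is hidden by the limit. The pair compound 1 and compound 2 shows only two limits and no readable step.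

Compound 4, `CCCSc1nc(N/N=C/c2cccc(Cl)c2)c2nnn(Cc3ccccc3)c2n1`, is not yet measured. It differs from compound 3 as 3-chlorophenyl in place of 4-nitrophenyl on a carbon with a double bond to nitrogen. Going by the values given here, this is the reverse of the change behind an at least 9.6-fold lower number from compound 2 to compound 3 (0.98 log units; beyond the scatter), combined with a move of the chlorine from 4-chlorophenyl to 3-chlorophenyl; no measured pair isolates that second part. The step from compound 3 to compound 4 in this assay is therefore expected to be a rise, at least modest, of about a 9.0-fold higher number from compound 3 to compound 4 (0.96 log units; beyond the scatter). Compound 4 is estimated at 60000 nM, with a range of 20000 nM to 180000 nM, and the result may well be reported only as a limit, because the limit of > 64000 nM in this assay, at which 2 of the 3 values shown sit, is where both chloro- and fluoro-bearing analogues already sit.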

Compound 4, half-maximal inhibitory concentration: > 64000 nM
Compound 4 was reported as a limit (the forecaster's own chance of this, stated with the estimate: 65%); at least 1.0-fold (0.02 log units) between middle value and limit.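

In this assay compound 4 gives > 64000 nM, a limit of the assay and not a number. With 3-chlorophenyl in place of 4-nitrophenyl on a carbon with a double bond to nitrogen, the change reads as an at least 9.6-fold higher number from compound 3 to compound 4 (0.98 log units; beyond the scatter), so a chlorine at this second ring location also fails to produce the measurable value seen with 4-nitrophenyl. The steps from compound 1 and from compound 2 to compound 4 join two limits and cannot be read, so any effect of moving the chlorine stays hidden, and the series now shows one numerical value against a common ceiling: the limit of > 64000 nM in this assay, at which 3 of the 4 values shown sit.

The compounds shown leave open whether a measurable value is particular to nitro, or whether an amine, a carboxylic acid or a methoxy group on the same aromatic carbon would also give one. Going by these compounds, all four compounds share the same core and its other substituents, so the contribution of those parts, and how much weaker than compound 3 the three limit compounds truly are, remains unknown.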